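The source may hold more compounds than are shown below. What is called first, only, known or untested is meant among the compounds shown, and "the series" means these compounds.

Working notes on the series in a functional assay (aorta) with Oryctolagus cuniculus as the target; a higher number here means a weaker inhibitor, a lower number a stronger inhibitor.

Two compounds have numbers. Compound 1, `CCO/C(O)=C1\C(C)=NC(C)=C(C(=O)OCCCN2C(=O)c3ccccc3S2(=O)=O)C1c1cccc([N+](=O)[O-])c1`, gives 1.9 nM. Compound 2, `CO/C(O)=C1\C(C)=NC(C)=C(C(=O)OCCCN2C(=O)c3ccccc3S2(=O)=O)C1c1cccc(Cl)c1Cl`, gives 0.8 nM and stands lowest of the two, with compound 1 as the nearest neighbour; the two differ in more than one place, so their values show only that the gap exceeds the scatter, nothing about either change on its own.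

Compound 3, `CCO/C(O)=C1\C(C)=NC(C)=C(C(=O)OCCCN2C(=O)c3ccccc3S2(=O)=O)C1c1cccc(Cl)c1Cl`, is not yet measured. It differs from compound 2 by methyl in place of hydrogen on a saturated chain carbon bound to an oxygen on an unsaturated carbon; the same difference, cut one bond further out, reads methyl to ethyl, methoxy to ethoxy. Within the data shown here, no pair of measured compounds isolates this change, so nothing here tells its size. The expectation is a step of a 1.1-fold higher number from compound 2 to compound 3 (0.05 log units; within the scatter), that is, no change beyond the scatter in either direction. Compound 3 is therefore estimated at 0.9 nM, with a range from 0.3 nM to 3 nM.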

Compound 3, half-maximal inhibitory concentration: 1.8 nM
Compound 3: middle estimate off by 2.0-fold (0.30 log units), on the low side, within the range that was stated.
By their numbers in this assay, from the lowest: compound 2; then compounds 3 and 1 (each within the scatter of the next).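

In this assay, among these compounds, the change from methoxy to ethoxy, methyl in place of hydrogen on a saturated chain carbon bound to an oxygen on an unsaturated carbon, gives a 2.3-fold higher number from compound 2 to compound 3 (0.35 log units; beyond the scatter) with 2,3-dichlorophenyl held constant, the first isolated reading at this position and a modest loss of potency. On the saturated ring carbon, 2,3-dichlorophenyl in place of 3-nitrophenyl gives a 1.1-fold lower number from compound 1 to compound 3 (0.02 log units; within the scatter) with ethoxy held constant, so this pair does not separate the two aryl groups. No measurement shown here bears on the reason for either step.

As far as these compounds go, whether the methoxy to ethoxy step holds with 3-nitrophenyl on the ring carbon remains open. Also open, from the compounds shown here alone, is how a longer chain such as propoxy, or a chain ending in an amine or a carboxylic acid, would read at this position.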